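The source may report more compounds than this note shows. Statements on the series, on what has been measured and on what is new or still open speak of the compounds shown alone.

Working notes on the series. In a functional assay, read by spectrophotometry, with a stated time of 5 min (on this read-out lower numbers stand for stronger inhibition and higher numbers for weaker inhibition), compound 1 `CCOc1cc(C=C(C(=O)/C=C/c2ccc(O)c(OC)c2)C(=O)/C=C/c2ccc(O)c(OC)c2)ccc1O` gives 123000000 nM. Compound 2 `COc1cc(/C=C/C(=O)C(=Cc2ccc(O)cc2)C(=O)/C=C/c2ccc(O)c(OC)c2)ccc1O` gives 48700000 nM in this assay. Compound 3 `CCOc1cc(C=C(C(=O)/C=C/c2ccc(O)c(OCC)c2)C(=O)/C=C/c2ccc(O)c(OCC)c2)ccc1O` gives 96700000 nM in this assay. Among the measured compounds shown here, the one counted step among the measured compounds, a 2.5-fold lower number from compound 1 to compound 2 (0.40 log units; beyond the scatter), belongs to the change (hydrogen in place of ethoxy on an aromatic carbon). Compound 3 and compound 1 differ in more than one place; the difference between the two cores is not broken down here. The values of compound 3 and compound 1 sit within the usual scatter of each other, as do the values of compound 3 and compound 2, so no order between them is claimed. Compound 4 `CCOc1cc(/C=C/C(=O)C(=Cc2ccc(O)cc2)C(=O)/C=C/c2ccc(O)c(OCC)c2)ccc1O` is compound 3 after the change (hydrogen in place of ethoxy on an aromatic carbon). The surroundings of the place are described in the same words for both pairs, so this is the same change as that from compound 1 to compound 2, seen only once so far. For the measured compounds named here, compound 4 is expected to show the step of a 2.4-fold lower number from compound 3 to compound 4 (0.38 log units; beyond the scatter), resting on the single measured instance a 2.5-fold lower number from compound 1 to compound 2 (0.40 log units; beyond the scatter). Compound 4 is accordingly estimated at 40000000 nM in this assay, with a likely range from 20000000 nM to 90000000 nM.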

Compound 4, half-maximal inhibitory concentration: 48000000 nM
For compound 4 the middle estimate is 1.2-fold (0.08 log units) below the measured one; the measured number falls inside the stated range.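

In this assay, hydrogen in place of ethoxy on the 3-ethoxy-4-hydroxyphenyl group gives a 2.0-fold lower number from compound 3 to compound 4 (0.30 log units; within the scatter), so on this core the change alone does not separate the two compounds. Set beside the earlier step, the result gives no sign that the change behaves differently on the two cores: the same change on two cores in this assay, a 2.5-fold lower number (0.40 log units; beyond the scatter) from compound 1 to compound 2 and a 2.0-fold lower number (0.30 log units; within the scatter) from compound 3 to compound 4, 1.3-fold (0.10 log units) apart, within the scatter of two such steps. Among the compounds shown here, this supports carrying the step from one of these cores to the other, but it rests on only two pairs, one of them within the scatter, and it shows neither that the step would hold on any further core nor why it arises.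

The compounds shown compare only ethoxy and hydrogen at this place, so it remains open how a longer chain such as butoxy, an amine or a carboxylic acid on the same aromatic carbon would read in this assay. Also open is whether the same change would give a comparable step on the other aromatic rings of these compounds.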